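The compounds below may be only part of what the source reports. "The series", "measured", "known", "first", "only" and "open" are said of these compounds alone.

Compound 3 `CCOC(=O)c1oc2cc(C3CCCCC3)cc(O)c2c1C` is one of three compounds whose toxicity to cultured cells has been measured in a functional assay on VA-13 cells (Homo sapiens) for cytotoxicity; on this read-out higher numbers stand for an effect only at larger amounts of compound and lower numbers for an effect already at smaller amounts. In this assay compound 3 gives > 4 ug/mL, which is a limit of the assay rather than a number. Compound 1 `CCCOc1ccc(-c2cc(O)c3c(C)c(C(=O)OCC)oc3c2)cc1` likewise gives > 4 ug/mL in this assay, again a limit. Compound 2 `CCOC(=O)c1oc2cc(-c3ccc(OCCc4ccccc4)cc3)cc(O)c2c1C` gives > 4 ug/mL in this assay, also a limit. Compound 4 `CCOC(=O)c1oc2cc(CC(C)(C)C)cc(O)c2c1C` differs from compound 3 by neopentyl in place of cyclohexyl on an aromatic carbon. Going by the values given here, the single step between measured compounds, a step that the two limits leave unreadable from compound 1 to compound 2, cannot be read, and the limit of > 4 ug/mL in this assay, at which 3 of the 3 values shown sit, is all that the measurements so far offer. The step that the limit leaves unreadable from compound 3 to compound 4 is therefore expected to be no larger than the scatter. Compound 4 is estimated at 8 ug/mL, within a range from 4 ug/mL to 30 ug/mL.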

Compound 4, half-maximal effective concentration: > 4 ug/mL
Compound 4 was reported as a limit (the forecaster's own chance of this, stated with the estimate: 80%); the middle value is on the limit's open side.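

Compound 3 and compound 4 each give only a limit, so the step between them cannot be read. On these data alone, how much of any of the four compounds is needed for an effect in this assay stays open, as does whether neopentyl and cyclohexyl differ there at all.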